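Working notes on an agonist series: estimating compound 3

The compounds below may be only part of what the source reports. "The series", "measured", "known", "first", "only" and "open" are said of these compounds alone.

Measured so far:
compound 1 `c1ccc2c(c1)CC2CCCCN1CCN(c2cccc3c2OCCO3)CC1` — > 10 mg/kg
compound 2 `c1ccc2c(c1)CC(CN1CCN(c3cccc4c3OCCO4)CC1)C2` — > 10 mg/kg

In a functional assay on the whole organism for agonist activity, with Rattus norvegicus as the target (a lower number here means that less compound is needed, a higher number that more compound is needed for the effect), compound 1 gives only a limit, > 10 mg/kg. Compound 2 likewise gives only a limit, > 10 mg/kg. For the measured compounds named here, compound 1 therefore sits where every value so far sits, at the limit of > 10 mg/kg in this assay, at which 2 of the 2 values shown sit, so its place among the numbers is a limit and not a rank.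

Compound 3 `Clc1cccc2c1CC2CCCN1CCN(c2cccc3c2OCCO3)CC1` differs from compound 1 by a group of 9 heavy atoms (8 carbon, 1 chlorine; one four-membered non-aromatic ring of carbon only, one six-membered aromatic ring of carbon only) in place of a group of 9 heavy atoms (9 carbon; one four-membered non-aromatic ring of carbon only, one six-membered aromatic ring of carbon only), on a saturated chain carbon, three bonds along the chain from an amine nitrogen in a ring. Going by the values given here, no measured step of this kind exists, so the expected step in this assay cannot be anchored beyond the scatter in either direction. Compound 3 is expected near 10 mg/kg, within 3 mg/kg to 30 mg/kg. The step this estimate means is a number no higher from compound 1 to compound 3 (the limit leaves the size open).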

Compound 3, minimum effective dose: > 10 mg/kg
Compound 3 was reported as a limit (the forecaster's own chance of this, stated with the estimate: 70%); the middle value lies on the limit itself.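

In this assay compound 3 gives > 10 mg/kg, which is a limit. Compound 1 also gives only a limit, and no step can be read between compound 1 and compound 3. The compounds shown leave open what dose, if any, produces the effect for any of them.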